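Swapping Methyl for Fluoro on the Amide Aryl Ring

This account rests on a few compounds, and the source may have more. Where it says the series, first, only, none or still open, it means among the compounds named here.

compound 1 `COc1ccc2c(=O)c(/C=C/C(=O)Nc3cccc(Cl)c3)coc2c1` — > 100000 nM (a limit)
compound 2 `COc1ccc2c(=O)c(/C=C/C(=O)Nc3ccc(C)cc3)coc2c1` — 39300 nM
compound 3 `COc1ccc2c(=O)c(/C=C/C(=O)NCc3ccccc3)coc2c1` — > 100000 nM (a limit)

Of the compounds shown here, three sharing one core have been tested in a functional assay (QGY7701 cells, Homo sapiens) for inhibition, read by MTT assay, with a stated time of 48 h; on this read-out lower numbers stand for stronger inhibition and higher numbers for weaker inhibition. Compound 1 reaches only the assay limit, > 100000 nM. Compound 3 likewise gives only a limit, > 100000 nM. Among the compounds with values here, compound 2 gives 39300 nM, the single real number of the three, while the other two sit at the limit of > 100000 nM in this assay, at which 2 of the 3 values shown sit. The measured steps are an at least 2.5-fold lower number from compound 1 to compound 2 (0.40 log units; beyond the scatter), an at least 2.5-fold higher number from compound 2 to compound 3 (0.40 log units; beyond the scatter) and a step that the two limits leave unreadable from compound 1 to compound 3.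

Compound 4 `COc1ccc2c(=O)c(/C=C/C(=O)Nc3ccc(F)cc3)coc2c1` differs from compound 2 by fluoro in place of methyl on an aromatic carbon. Neither measured step swaps one small group for another on a 4-substituted phenyl: each replaces the whole group on the amide-type nitrogen. Within the data shown here, they show only that compound 2 carries the one group that produced a readable number, and that moving away from it gave limits. A fluoro group in place of the methyl is therefore expected to give a somewhat higher number, a 1.5-fold higher number from compound 2 to compound 4 (0.18 log units; within the scatter), with a real chance that only a limit is recorded. Compound 4 is estimated at 60000 nM, between 25000 nM and 120000 nM.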

Compound 4, half-maximal inhibitory concentration: > 100000 nM
Compound 4 was reported as a limit (the forecaster's own chance of this, stated with the estimate: 40%); at least 1.6-fold (0.22 log units) between middle value and limit.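

In this assay, replacing only the methyl with fluoro gives an at least 2.5-fold higher number from compound 2 to compound 4 (0.40 log units; beyond the scatter), so a change of a single heavy atom on this phenyl ring is enough to lose the readable number, something the earlier swaps of the whole group on the amide nitrogen could not show. Compound 4 is recorded only as a limit, and it joins the other compounds there: the limit of > 100000 nM in this assay, at which 3 of the 4 values shown sit. Within the data shown here, the steps among compound 1, compound 3 and compound 4 run from limit to limit and cannot be read, so compound 2 remains the only compound with a real number.

From the compounds shown here alone, the true size of the methyl-to-fluoro step stays open, since a limit gives no end point. Also open, going by these compounds, is whether an ethyl group or an amine at this place would keep a readable number, as the methyl does.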